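Lengthening the amide chain by one carbon

A few compounds are considered here, and "the series" means these few. Any claim that something is new, unique, unknown or untested is made for them only; others in the source may bear on it.

Compound 3 `COc1cccc(Oc2ccc(NC(C)=O)cc2)c1` gives 84 nM in an assay on isolated protein for binding affinity to melatonin receptor type 1A (Homo sapiens) (on this read-out higher numbers stand for weaker inhibition and lower numbers for stronger inhibition), the highest of the two numbers shown; compound 1 `CCCC(=O)Nc1ccc(Oc2cccc(OC)c2)cc1` sits close with 63 nM, within the scatter. Compound 2 `CCCC(=O)Nc1ccc(Oc2ccc(OC)cc2)cc1` is reported only as a limit of this assay, > 500 nM, with no number (the limit of > 500 nM in this assay, at which 1 of the 3 values shown sits). Compound 4 `CCC(=O)Nc1ccc(Oc2cccc(OC)c2)cc1` differs from compound 3 by methyl in place of hydrogen on a saturated chain carbon bound to a carbonyl carbon. Within the data shown here, the one measured step at this position, a 1.3-fold higher number from compound 1 to compound 3 (0.12 log units; within the scatter), removed an ethyl group and moved the number by an amount within the scatter. The shorter addition here is therefore expected to bring no change beyond the scatter, a step of a 1.2-fold lower number from compound 3 to compound 4 (0.08 log units; within the scatter). Compound 4 is estimated at 70 nM, between 35 nM and 140 nM.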

Compound 4, inhibition constant: 300 nM
Beside the measured number, compound 4's estimate is 4.3-fold (0.63 log units) below it; the whole stated range lies below it.
By their numbers in this assay, from the lowest: compounds 1 and 3 (each within the scatter of the next); then compound 4. At a limit, above all of these: compound 2.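

Adding methyl on the saturated chain carbon bound to a carbonyl carbon gives a 3.6-fold higher number from compound 3 to compound 4 (0.55 log units; beyond the scatter) in this assay, so this position is sensitive to a single added carbon. Taking a methyl off the chain of compound 1 likewise gives a 4.8-fold higher number from compound 1 to compound 4 (0.68 log units; beyond the scatter), which shows that chain length does not act in one steady direction: compound 4 falls out of line with compounds 1 and 3, which stay within the scatter of each other. Nothing shown accounts for this.

From the compounds shown here alone, whether a longer chain, a branched chain or an amine at this position would track compound 4 or compounds 1 and 3 remains open.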